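From pyridin-4-yl to 2-chloropyridin-4-yl

A few compounds are considered here, and "the series" means these few. Any claim that something is new, unique, unknown or untested is made for them only; others in the source may bear on it.

In a functional assay on MCF7 cells (Homo sapiens) for cytotoxicity, read by MTT assay and propidium iodide staining, with a stated time of 24 h (a higher number here means a weaker inhibitor, a lower number a stronger inhibitor), compound 1 (`Cc1ccc(-c2nnc(SCC(=O)c3ccccc3)o2)c(O)c1`) gives 150 nM and compound 3 (`COc1ccc(-c2nnc(SCC(=O)c3ccccc3)o2)c(O)c1`) gives 280 nM while compound 2 (`O=C(CSc1nnc(-c2ccncc2)o1)c1ccccc1`) gives 370 nM on the same read-out. The number for compound 2 lies within the scatter of the number for compound 3. It is higher than the number for compound 1 by more than the scatter, so compound 2 is the weaker of that pair.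

The next compound is compound 4 (`O=C(CSc1nnc(-c2ccnc(Cl)c2)o1)c1ccccc1`). It differs from compound 2 by chloro in place of hydrogen on an aromatic carbon, which turns pyridin-4-yl into 2-chloropyridin-4-yl.

Among the compounds with values here, only one measured step links compounds that differ in a single place. That step is a 1.9-fold higher number from compound 1 to compound 3 (0.27 log units; within the scatter) and it concerns methoxy in place of methyl on an aromatic carbon. It stays within the scatter and involves no chloro group, so it offers only a loose guide to the size of a single substitution. Within the data shown here, no measured step shows what chloro does here. No step beyond the scatter is therefore expected in this assay and no direction can be argued.

Among the measured compounds shown here, the estimated step is a 1.2-fold lower number from compound 2 to compound 4 (0.09 log units; within the scatter) (an expectation with no direct precedent). Compound 4 is expected at 300 nM (estimated range 120 nM to 750 nM).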

Compound 4, half-maximal inhibitory concentration: 1290 nM
For compound 4 the middle estimate is 4.3-fold (0.63 log units) below the measured one, and the stated range ends below it.
By their numbers in this assay, from the lowest: compounds 1, 3 and 2 (each within the scatter of the next, the first and the last beyond it); then compound 4.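

Chloro in place of hydrogen on the aromatic carbon next to the ring nitrogen gives the first single-place change in this assay that goes beyond the scatter (a 3.5-fold higher number from compound 2 to compound 4 (0.54 log units; beyond the scatter)), and compound 4 is the weaker of the pair. Within the data shown here, the only earlier step, methoxy in place of methyl (a 1.9-fold higher number from compound 1 to compound 3 (0.27 log units; within the scatter)), stayed within the scatter and so gave no sign that one small substitution could move the number clearly, whereas here one added chlorine atom does so, and the number goes up, not down. Nothing measured here explains why this position responds in this way.

The compounds shown carry only hydrogen or chloro at this place, so it remains open whether the higher number is particular to chloro or would also follow from a fluoro, a methyl or an amine on the same carbon. Going by these compounds, it is also open whether chloro elsewhere on the pyridine ring, or on the phenyl ring of the phenacyl end, would give a step of similar size.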